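Aryl variation on the triazole nitrogen in one series

The compounds below may be only part of what the source reports. "The series", "measured", "known", "first", "only" and "open" are said of these compounds alone.

compound 1 `N#CC1=C(N)Oc2c(c3nc4ccccc4nc3c3ccccc23)C12C(=O)N(Cc1cnnn1-c1ccc(S(N)(=O)=O)cc1)c1ccccc12`: 42200 nM in a functional assay on HepG2 cells (Homo sapiens) for antiproliferative activity, read by MTT assay, with a stated time of 48 h; a lower number here means a stronger inhibitor, a higher number a weaker inhibitor
compound 2 `Cc1ccc(-n2nncc2CN2C(=O)C3(C(C#N)=C(N)Oc4c3c3nc5ccccc5nc3c3ccccc43)c3ccccc32)c(C)c1`: > 50000 nM in this assay

Compound 2 stands at the limit of this assay, as the limit of > 50000 nM in this assay, at which 1 of the 2 values shown sits, shows, and no number is known for it. Compound 3 `Cc1ccc(-n2nncc2CN2C(=O)C3(C(C#N)=C(N)Oc4c3c3nc5ccccc5nc3c3ccccc43)c3ccccc32)cc1Cl` carries 3-chloro-4-methylphenyl in place of 2,4-dimethylphenyl on an aromatic nitrogen. For the measured compounds named here, the only measured step at this position, an at least 1.1-fold higher number from compound 1 to compound 2 (0.07 log units; that floor lies within the scatter), is no larger than the scatter, so changing the aryl on the aromatic nitrogen has so far moved nothing visible. For compound 3 the expected step is a step that the limit leaves unreadable from compound 2 to compound 3, nothing beyond the scatter. Compound 3 is therefore expected at 55000 nM, between 25000 nM and 150000 nM, and most likely it is again reported only as a limit.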

Compound 3, half-maximal inhibitory concentration: > 50000 nM
Compound 3: only a limit was reported (the forecaster's own chance of this, stated with the estimate: 65%); the middle value does not contradict the limit.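

Replacing the methyl of 2,4-dimethylphenyl with the chlorine-bearing 3-chloro-4-methylphenyl gives no readable shift, and the step between these two aryl groups cannot be read: the limit of > 50000 nM in this assay, at which 2 of the 3 values shown sit.
Against 4-sulfamoylphenyl, 3-chloro-4-methylphenyl gives an at least 1.1-fold higher number from compound 1 to compound 3 (0.07 log units; that floor lies within the scatter), the same floor as the dimethyl aryl, so chlorine on the aryl separates nothing from the sulfamoyl compound.

Still open, going by these compounds, is whether any group on this aromatic nitrogen can bring a number clearly lower in this assay. An aryl bearing an amine or a carboxylic acid, or a longer alkyl chain in place of the aryl, would test this.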